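A few compounds are considered here, and "the series" means these few. Any claim that something is new, unique, unknown or untested is made for them only; others in the source may bear on it.

In an in vivo ADME assay on the whole organism for pharmacokinetics, at a dose of 0.5 mg/kg by the intravenous route (a lower number here means that more of the compound stays in the plasma, a higher number that more of the compound sits outside the plasma), compound 2 `Cn1nc(-c2ccc(C(N)=O)cc2)s/c1=N\C1CCCCC1` gives 7.65 L/kg, the highest of the two single numbers in this set. Compound 1 `CC(=O)Nc1ccc(-c2nn(C)/c(=N/C3CCCC(O)C3)s2)cc1` gives 2.02 L/kg, a lower value, and the gap between compound 1 and compound 2 lies beyond the usual scatter. Compound 3 `Cn1nc(-c2ccc(S(C)(=O)=O)cc2)s/c1=N\C1CCCC(O)C1` has several entries in this assay, giving 0.92 L/kg; 0.62 L/kg (2 entries) (the several entries of compound 3 in this assay, 0.92 L/kg; 0.62 L/kg (2 entries)), so no single number stands for it. Compound 4 `Cn1nc(-c2ccc(C(N)=O)cc2)s/c1=N\C1CCCCC1O` has not been measured in this assay. It differs from compound 2 in one place: hydroxy in place of hydrogen on a saturated ring carbon. For the measured compounds named here, no pair of measured compounds differs in only this way, so the size of the step has to be judged from the whole set. Both compounds that carry a hydroxy on the saturated ring, compound 1 and compound 3, sit below compound 2, though each also differs from compound 2 elsewhere on the shared core. The step is therefore expected to be downward, estimated at a 2.6-fold lower number from compound 2 to compound 4 (0.41 log units; beyond the scatter), beyond the scatter. The estimate for compound 4 in this assay is 3 L/kg, with a range from 1.4 L/kg to 6.5 L/kg.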

Compound 4, volume of distribution: 1.47 L/kg
Beside the measured number, compound 4's estimate is 2.0-fold (0.31 log units) above it, and the stated range covers the measured number.
By their numbers in this assay, from the lowest: compounds 4 and 1 (each within the scatter of the next); then compound 2.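

In this assay, for the compounds shown here, the change from cyclohexyl to 2-hydroxycyclohexyl gives a 5.2-fold lower number from compound 2 to compound 4 (0.72 log units; beyond the scatter), and this is the first reading of the hydroxy group on its own. Compounds 1 and 3 also carry a hydroxy on the saturated ring, but each differs from compound 2 elsewhere too, so neither could separate the effect of that group from the rest of the structure. Here the shift in the number belongs to this one change, at this ring carbon next to the ring atom that bears a large group, although nothing measured here gives a reason for it. The compounds shown leave open whether a methoxy group or an amine in the same place would move the number in the same direction. They also leave open whether the hydroxy would give a step of similar size on the cores of compound 1 and compound 3.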